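Swapping bromine for chlorine on a coumarin-linked diazine

A few compounds are considered here, and "the series" means these few. Any claim that something is new, unique, unknown or untested is made for them only; others in the source may bear on it.

Two compounds share a coumarin core carrying a six-membered aromatic ring with 2 nitrogen that bears a bromo group. Compound 1 `Cc1cccc2cc(-c3ccc(Br)nn3)c(=O)oc12` and compound 2 `COc1ccc2cc(-c3ccc(Br)nn3)c(=O)oc2c1` differ only in the substituent on the coumarin side. In an assay on cells for inhibition of Amine oxidase [flavin-containing] B (Homo sapiens), read by fluorescence and Amplex Red, with a stated time of 15 min (a higher number here means a weaker inhibitor, a lower number a stronger inhibitor), compound 1 gives 2640 nM, and in the same setting compound 2 gives 3050 nM. Compound 2 holds the highest of the two numbers, yet its neighbour compound 1 lies within the scatter of repeated measurements, so no order between them can be claimed.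

Compound 3 `COc1ccc2cc(-c3ccc(Cl)nn3)c(=O)oc2c1` is the next step: chloro in place of bromo on an aromatic carbon. No step between measured compounds here has exchanged one halogen for another, so the size and direction of this change cannot be read from the shown data. The step from compound 2 to compound 3 is expected to stay within the scatter, a 1.1-fold higher number from compound 2 to compound 3 (0.06 log units; within the scatter). Compound 3 is therefore estimated at 3500 nM in this assay, with a range from 1500 nM to 8000 nM.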

Compound 3, half-maximal inhibitory concentration: 19200 nM
For compound 3 the middle estimate is 5.5-fold (0.74 log units) below the measured one; the measured number lies above the stated range.
By their numbers in this assay, from the lowest: compounds 1 and 2 (each within the scatter of the next); then compound 3.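

In this assay the halogen at this position proves not to be interchangeable: chloro in place of bromo gives a 6.3-fold higher number from compound 2 to compound 3 (0.80 log units; beyond the scatter) and lies beyond the scatter. Compounds 1 and 2 both carry bromo, so they could not show that this aromatic carbon, next to the ring nitrogen and para to a large group, responds to a change of halogen. In this single pair the bromo compound 2 has the lower number, but nothing shown here accounts for the difference. 

The compounds shown leave open whether the same exchange on the core of compound 1 would produce a step of similar size and direction. They also leave open how an amine or a nitrile at this position would compare with bromo and chloro.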